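The source may report more compounds than this note shows. Statements on the series, on what has been measured and on what is new or still open speak of the compounds shown alone.

Measured in a functional assay on MCF7 cells (Homo sapiens) for cytotoxicity, read by MTT assay, with a stated time of 72 h; a lower number here means a stronger inhibitor, a higher number a weaker inhibitor:
- compound 1 `O=C1c2c[n+]([O-])c3ccccc3c2C(=O)c2c1c1ccccc1n2Cc1cn([C@@H]2C[C@H](O)[C@@H](CO)O2)nn1`: 110 nM
- compound 2 `O=C1c2c[n+]([O-])c3ccccc3c2C(=O)c2c1c1ccccc1n2CCN1CCCC1`: 320 nM
- compound 3 `CC1(C)OC[C@@H](Cn2cc(Cn3c4c(c5ccccc53)C(=O)c3c[n+]([O-])c5ccccc5c3C4=O)nn2)O1`: > 1000 nM (a limit of the assay, not a number)

Of the two exact numbers in the series, compound 2 has the higher at 320 nM, and compound 1 lies lower at 110 nM.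

Compound 4 `CN(C)CCCCn1c2c(c3ccccc31)C(=O)c1c[n+]([O-])c3ccccc3c1C2=O` has not yet been measured. It differs from compound 2 as follows: 2-(dimethylamino)ethyl in place of pyrrolidin-1-yl on a saturated chain carbon, two bonds along the chain from an aromatic nitrogen. In words, this is 2-(dimethylamino)ethyl in place of pyrrolidin-1-yl on a saturated chain carbon, two bonds along the chain from an aromatic nitrogen. Cut one bond further out, it reads 2-(pyrrolidin-1-yl)ethyl to 4-(dimethylamino)butyl.

Among the compounds with values here, only one measured step is available, an at least 9.0-fold higher number from compound 1 to compound 3 (0.95 log units; beyond the scatter), and it bears on this change only loosely. That change sits on an aromatic nitrogen rather than on a saturated chain carbon, and it swaps different groups. Within the data shown here, it shows only that side-chain changes can move the number in this assay.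

Among the measured compounds shown here, with no closer precedent, no shift beyond the scatter is expected, and the estimated step is a 1.1-fold lower number from compound 2 to compound 4 (0.03 log units; within the scatter). For compound 4 the expected value is 300 nM, with an estimated range of 100 nM to 900 nM.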

Compound 4, half-maximal inhibitory concentration: 220 nM
Compound 4: middle estimate off by 1.4-fold (0.13 log units), on the high side; low and high end bracket the measured number.
By their numbers in this assay, from the lowest: compounds 1, 4 and 2 (each within the scatter of the next, the first and the last beyond it). At a limit, above all of these: compound 3.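

In this assay, within the data shown here, the first measured step at this chain position is a 1.5-fold lower number from compound 2 to compound 4 (0.16 log units; within the scatter), so replacing the pyrrolidin-1-yl ring with the open 2-(dimethylamino)ethyl group leaves the number within the scatter. The change keeps the heavy-atom count and the hydrogen-bond acceptor count, and the side chain of compound 4, a 4-(dimethylamino)butyl group, stands in for the 2-(pyrrolidin-1-yl)ethyl group of compound 2 without a shift that can be read. No available measurement bears on the reason for this step.

Among these compounds, the single step joins loss of the ring with a longer chain, so the two cannot be separated here; a 2-(dimethylamino)ethyl chain on the aromatic nitrogen would address that. From the compounds shown here alone, whether the chain must end in an amine stays open, and a terminal hydroxyl group or carboxylic acid would test it.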